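Dihydrofuran carboxamides: amide nitrogen substituent, compound 4

The source may report more compounds than this note shows. Statements on the series, on what has been measured and on what is new or still open speak of the compounds shown alone.

Measured compounds:
Compound 1 `C=CC1=C(C(=O)NC(C)(C)C)C(c2ccc(OC)cc2)OC1`. In a functional assay on QGY7701 cells (Homo sapiens) for cytotoxicity, read by MTT assay, with a stated time of 24 h (on this read-out higher numbers stand for weaker inhibition and lower numbers for stronger inhibition), compound 1 gives > 100000 nM, a limit of the assay.
Compound 2 `C=CC1=C(C(=O)NC(C)(C)C)C(c2ccc(F)cc2)OC1`. In this assay compound 2 gives > 100000 nM, a limit of the assay.
Compound 3 `C=CC1=C(C(=O)NCc2ccc(OC)c(OC)c2)C(c2ccc(F)cc2)OC1`. In this assay compound 3 gives 87300 nM.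

Compound 1 stands only at the limit of > 100000 nM in this assay, at which 2 of the 3 values shown sit; no number is available for it. Among the compounds with values here, the one step computed between measured compounds, a step that the two limits leave unreadable from compound 1 to compound 2, changes the aryl substituent, not the amide nitrogen, and because both ends sit at the limit of > 100000 nM in this assay, at which 2 of the 3 values shown sit, its size cannot be read.

Compound 4 `C=CC1=C(C(=O)NCc2ccc(C)cc2)C(c2ccc(OC)cc2)OC1` differs from compound 1 as follows: 4-methylbenzyl in place of tert-butyl on an amide-type nitrogen. Within the data shown here, no computed step touches this position. Among the measured compounds shown here, compound 3 carries a benzyl-type group on the amide nitrogen and gives a number rather than a limit, but compound 3 also differs from compound 1 in the aryl substituent, so it shows only that such a compound can fall within the measured range.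

With no readable step to draw on, the expected step of an at least 1.1-fold lower number from compound 1 to compound 4 (0.04 log units; that floor lies within the scatter) from compound 1 to compound 4 is none beyond the scatter, and compound 4 is estimated at 90000 nM, within 40000 nM to 200000 nM, with a substantial chance that only a limit is reported.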

Compound 4, half-maximal inhibitory concentration: 43100 nM
Estimate against measurement, compound 4: 2.1-fold (0.32 log units) above; the range from low to high includes it.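

In this assay, the amide nitrogen is now seen to be a position that can shift the read-out: with the methoxy-bearing aryl group held constant, 4-methylbenzyl in place of tert-butyl gives an at least 2.3-fold lower number from compound 1 to compound 4 (0.36 log units; beyond the scatter) and so moves the series off the limit. Only a minimum can be read for this step, not its full size, because compound 1 has no number of its own: the limit of > 100000 nM in this assay, at which 2 of the 4 values shown sit. On the fluoro aryl group the printed values point the same way. Compound 2, with tert-butyl, stays at a limit of the assay. Compound 3, with a benzyl-type group on the amide nitrogen, gives 87300 nM as a number.

The compounds shown leave open whether the gain follows the aromatic ring itself or its methyl group, which an unsubstituted benzyl or a 4-chlorobenzyl group on the amide nitrogen would help to separate. Also open, from the compounds shown here alone, is how an amine or a carboxylic acid at the end of a longer chain on that nitrogen would read on the shared core.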